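The compounds below may be only part of what the source reports. "The series", "measured", "known", "first", "only" and "open" are said of these compounds alone.

Compound 3 `Oc1cccc(-c2cc(-c3cccc(O)c3)nc(-c3ccccc3O)c2)c1` is the starting point. In a functional assay on HCT-15 cells (Homo sapiens) for cytotoxicity, read by CCK-8 assay, with a stated time of 4 days (a lower number here means a stronger inhibitor, a higher number a weaker inhibitor), compound 3 gives only a limit, > 50000 nM, and not a number. For the measured compounds named here, the one member of the set with a number is compound 1 `Oc1ccc(-c2cc(-c3cccc(O)c3)nc(-c3ccccc3O)c2)cc1`, which in this assay gives 5830 nM. Compound 2 `Oc1ccc(-c2cc(-c3ccccc3O)nc(-c3ccccc3O)c2)cc1` likewise returns only a limit in this assay, > 50000 nM. Two steps frame the picture: an at least 8.5-fold higher number from compound 1 to compound 3 (0.93 log units; beyond the scatter) and an at least 8.5-fold higher number from compound 1 to compound 2 (0.93 log units; beyond the scatter), both ending at the limit of > 50000 nM in this assay, at which 2 of the 3 values shown sit. Compound 4 `Oc1cccc(-c2cc(-c3ccccc3O)nc(-c3ccccc3O)c2)c1` differs from compound 3 by 2-hydroxyphenyl in place of 3-hydroxyphenyl on an aromatic carbon; the same exchange runs from compound 1 to compound 2, where it gave an at least 8.5-fold higher number from compound 1 to compound 2 (0.93 log units; beyond the scatter). Compound 3 already sits at the limit. Compound 4 is therefore expected to remain there, with a step that the limit leaves unreadable from compound 3 to compound 4 and an estimated value of 100000 nM, ranging from 40000 nM to 300000 nM.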

Compound 4, half-maximal inhibitory concentration: 5020 nM
The estimate for compound 4 lay 20-fold (1.30 log units) above the measured number; the whole stated range lies above it.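

In this assay, 2-hydroxyphenyl in place of 3-hydroxyphenyl next to the ring nitrogen gives an at least 9.9-fold lower number from compound 3 to compound 4 (0.99 log units; beyond the scatter). The direction of this change thus reverses with the core that carries it: the same change on two cores in this assay, an at least 8.5-fold higher number (0.93 log units; beyond the scatter) from compound 1 to compound 2 and an at least 9.9-fold lower number (0.99 log units; beyond the scatter) from compound 3 to compound 4, at least 85-fold (1.93 log units) apart, beyond the scatter of two such steps. The exchange of 4-hydroxyphenyl for 3-hydroxyphenyl likewise gives an at least 9.9-fold lower number from compound 2 to compound 4 (0.99 log units; beyond the scatter), and it reverses too: the same change on two cores in this assay, an at least 8.5-fold higher number (0.93 log units; beyond the scatter) from compound 1 to compound 3 and an at least 9.9-fold lower number (0.99 log units; beyond the scatter) from compound 2 to compound 4, at least 85-fold (1.93 log units) apart, beyond the scatter of two such steps. The compounds shown leave open whether an amine or a methoxy group in place of the hydroxyl of the 2-hydroxyphenyl group would preserve the number of compound 4, 5020 nM.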